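Aryl swap on the core: compound 2 to compound 4

A few compounds are considered here, and "the series" means these few. Any claim that something is new, unique, unknown or untested is made for them only; others in the source may bear on it.

Among the measured compounds shown here, compound 2 `Clc1cccc(-c2nc3sccn3c2/C=N/OCc2ccc(Cl)c(Cl)c2)c1` stands lowest of the three numbers measured so far, giving 1100 nM in an assay on HepG2 cells for agonist activity at nuclear receptor subfamily 1 group I member 3 (Homo sapiens), read by a luciferase reporter, with a stated time of 23 h; on this read-out lower numbers stand for an effect already at smaller amounts and higher numbers for an effect only at larger amounts of compound. Compound 3 `Fc1c(F)c(F)c(CO/N=C/c2c(-c3ccc4ccccc4c3)nc3occn23)c(F)c1F` gives 1700 nM, within the scatter of compound 2, while compound 1 `COc1ccc(CO/N=C/c2c(-c3ccc4ccccc4c3)nc3occn23)cc1` gives 4400 nM, beyond it. For the measured compounds named here, the only single-point step recorded, a 2.6-fold lower number from compound 1 to compound 3 (0.41 log units; beyond the scatter), concerns the group on the saturated chain carbon bound to oxygen, not the aromatic carbon changed here. Compound 4 `Clc1ccc(CO/N=C/c2c(-c3ccc4ccccc4c3)nc3sccn23)cc1Cl` differs from compound 2 by naphthalen-2-yl in place of 3-chlorophenyl on an aromatic carbon. Going by the values given here, no measured pair isolates this change; compounds 1 and 3 carry naphthalen-2-yl on a different core and with other chain groups, so their numbers do not settle a direction. For compound 4 the expected step is therefore a 1.1-fold lower number from compound 2 to compound 4 (0.04 log units; within the scatter), within the scatter. Compound 4 is estimated at 1000 nM, range 300 nM to 3500 nM.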

Compound 4, half-maximal effective concentration: 380 nM
Estimate against measurement, compound 4: 2.6-fold (0.42 log units) above, and the stated range covers the measured number.
By their numbers in this assay, from the lowest: compound 4; then compounds 2 and 3 (each within the scatter of the next); then compound 1.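

In this assay the aromatic carbon bearing the aryl group responds to substitution: a 2.9-fold lower number from compound 2 to compound 4 (0.46 log units; beyond the scatter), the first step read at this position. The swap adds a second six-membered aromatic ring of carbon only and removes the chlorine, and this single pair cannot separate those two changes. Nothing available here accounts for the step.

Open, as far as these compounds go, is whether an unsubstituted phenyl or a naphthalen-1-yl at this position would give a similar number. Also open, from the compounds shown here alone, is whether naphthalen-2-yl gives the same step on the core of compound 1.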